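Ring configuration versus solubility in the amide series

A few compounds are considered here, and "the series" means these few. Any claim that something is new, unique, unknown or untested is made for them only; others in the source may bear on it.

Of the compounds shown here, three have been measured in a physicochemical assay for solubility; on this read-out higher numbers stand for higher solubility and lower numbers for lower solubility. Compound 1 `C[C@@H]1[C@@H](NC(=O)[C@@H](C)N)CN1c1nc2c(cc1F)c(=O)c(C(=O)O)cn2C1CC1` gives > 500 ug/mL in this assay. That value is a limit of the assay, not a number. Compound 2 `CC(C)C[C@H](N)C(=O)N[C@@H]1CN(c2nc3c(cc2F)c(=O)c(C(=O)O)cn3C2CC2)[C@H]1C` gives > 500 ug/mL in this assay, which is again a limit. Compound 3 `CCC[C@H](N)C(=O)N[C@@H]1CN(c2cc3c(cc2F)c(=O)c(C(=O)O)cn3-c2ccc(F)cc2F)[C@H]1C` gives > 500 ug/mL in this assay, once more a limit. Within the data shown here, every value in hand therefore sits at the limit of > 500 ug/mL in this assay, at which 3 of the 3 values shown sit, so compound 1 stands where the other two stand, and no step between measured compounds can be counted: none of the three pairs differs in a single place, and each pair consists of two limits.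

Compound 4 `C[C@@H](N)C(=O)N[C@@H]1CN(c2nc3c(cc2F)c(=O)c(C(=O)O)cn3C2CC2)[C@H]1C` has not yet been measured in this assay. Relative to compound 1 it shows (the two compounds have the same atoms and bonds and differ only in configuration as drawn: 2 of 3 stereo elements differ; a stereocentre at a saturated ring carbon is drawn S in compound 1 and R in compound 4; a stereocentre at a saturated ring carbon is drawn R in compound 1 and S in compound 4). Only configuration changes; no atom leaves or enters. Among the measured compounds shown here, with no measured step available, the expectation is a step of no size beyond the usual scatter, a step that the limit leaves unreadable from compound 1 to compound 4, since compound 1 already reaches > 500 ug/mL and the change is confined to stereochemistry. Compound 4 is therefore expected to give about 600 ug/mL in this assay, within a range of 300 ug/mL to 1500 ug/mL, most likely reported again as a limit.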

Compound 4, solubility: 495 ug/mL
Beside the measured number, compound 4's estimate is 1.2-fold (0.08 log units) above it, within the range that was stated.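

In this assay, among these compounds, compound 4 gives 495 ug/mL, the first value that is a number rather than a limit. Compound 1 gives > 500 ug/mL, which is a limit. The values show a number no higher from compound 1 to compound 4 (the limit leaves the size open), and they show a number no higher from compound 2 to compound 4 (the limit leaves the size open). Neither step can be read in size, because one end of each is a limit: the limit of > 500 ug/mL in this assay, at which 3 of the 4 values shown sit.

Among the compounds shown here, whether the configuration at these ring carbons changes the read-out in this assay at all stays open, since the one pair that could show it has no readable step, although it isolates that single change: the fact that compounds 1 and 4 differ only in the configuration as drawn Also open is how a compound with 1-hydroxyethyl in place of 1-aminoethyl on the carbonyl carbon would read in this assay, which would separate the amine of this side chain from the rest of the structure.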